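A few compounds are considered here, and "the series" means these few. Any claim that something is new, unique, unknown or untested is made for them only; others in the source may bear on it.

Measured compounds
compound 1 `O=C(NCc1ccc(S(=O)(=O)c2ccccc2)cc1)c1nc2ccncc2s1` — 210 nM
compound 2 `O=C(NCc1ccc(S(=O)(=O)c2ccccc2C(F)(F)F)cc1)c1cc2cnccc2[nH]1` — 24 nM
compound 3 `O=C(NCc1ccc(S(=O)(=O)c2cccc(C(F)(F)F)c2)cc1)c1ccc2nccn2c1` — 8 nM

All three values come from an assay for inhibition of Nicotinamide phosphoribosyltransferase (Homo sapiens), read by mass spectrometry, with stated times of 15 min and 30 min; a lower number here means a stronger inhibitor, a higher number a weaker inhibitor. Compound 2 stands second highest of the three numbers. Its nearest neighbour is compound 3, whose value of 8 nM is the lower number by a margin beyond the usual scatter; compound 1, at 210 nM, lies furthest away, a higher number that is also beyond the scatter. Going by the values given here, no two of the measured compounds differ in only one place, so no single-change step is known within this set; each differs from the others both in the core and in the aryl group on the sulfonyl sulfur.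

Compound 4 `O=C(NCc1ccc(S(=O)(=O)c2ccc(F)cc2)cc1)c1cc2cnccc2[nH]1` keeps the core of compound 2 and changes only the aryl group on the sulfonyl sulfur: 4-fluorophenyl in place of 2-(trifluoromethyl)phenyl on a sulfonyl sulfur. Nothing measured here isolates this change. Compound 1 carries an unsubstituted phenyl on the sulfonyl sulfur and gives a higher number than compounds 2 and 3, but its core differs as well, so it cannot be read as a guide to the aryl group alone. The expected step from compound 2 to compound 4 in this assay is a 2.1-fold higher number from compound 2 to compound 4 (0.32 log units; beyond the scatter), toward a weaker inhibitor, of a size that may sit at the edge of the scatter. Compound 4 is estimated at 50 nM in this assay, with a range from 15 nM to 170 nM.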

Compound 4, half-maximal inhibitory concentration: 17 nM
Compound 4: middle estimate off by 2.9-fold (0.47 log units), on the high side; the range from low to high includes it.
By their numbers in this assay, from the lowest: compound 3; then compounds 4 and 2 (each within the scatter of the next); then compound 1.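

In this assay, going by these compounds alone, replacing 2-(trifluoromethyl)phenyl with 4-fluorophenyl on a sulfonyl sulfur gives the first single-place comparison, and it reads a 1.4-fold lower number from compound 2 to compound 4 (0.15 log units; within the scatter) on the core shared by the pair. With this core, the two aryl groups cannot be told apart in this read-out, so the trifluoromethyl group is not needed to hold a value in the range of compound 2 at 24 nM, and a single fluorine on the phenyl ring serves as well. No measurement available here bears on why the two groups read alike.

Still open, from the compounds shown here alone, is whether any substituent on this aryl group matters, as unsubstituted phenyl appears only on the different core of compound 1, and whether the same replacement would read alike on the core of compound 1 or compound 3. Also open, going by these compounds, is how this core would respond to a group further removed from these two on the sulfonyl sulfur, such as a phenyl ring carrying an amine or a carboxylic acid, or a simple alkyl chain in place of the aryl ring.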